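From Compound 1 to Compound 4 at the Melanocortin 4 Receptor

The source may report more compounds than this note shows. Statements on the series, on what has been measured and on what is new or still open speak of the compounds shown alone.

Of the compounds shown here, three sharing one core have been measured in an assay on HEK293 cells for displacement of a labelled ligand from Melanocortin receptor 4 (Homo sapiens); a higher number here means a weaker inhibitor, a lower number a stronger inhibitor. Compound 1 `CCC(C)C(N)c1cc(C(F)(F)F)ccc1N1CCN(C(=O)CCc2ccc(Cl)cc2Cl)CC1` gives 160 nM and stands lowest of the three. Compound 3 `CC(C)C[C@H](N)c1cc(C(F)(F)F)ccc1N1CCN(C(=O)CCc2c[nH]c3ccccc23)CC1` gives 640 nM, and compound 2 `CC(C)C[C@H](N)c1cc(C(F)(F)F)ccc1N1CCN(C(=O)CCc2ccccc2Cl)CC1` gives 1700 nM. The only single-point step among these is a 2.7-fold lower number from compound 2 to compound 3 (0.42 log units; beyond the scatter), a change on the chain that hangs from the carbonyl, far from the side of the core that is altered next.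

Compound 4 `CC(C)C[C@H](NC(=O)CN)c1cc(C(F)(F)F)ccc1N1CCN(C(=O)CCc2ccc(Cl)cc2Cl)CC1` differs from compound 1 in one place: 1-(((aminomethyl)carbonyl)amino)-3-methylbutyl in place of 1-amino-2-methylbutyl on an aromatic carbon. Going by the values given here, no measured pair in this set touches this position, so the step from compound 2 to compound 3 cannot speak to it, and the set offers no guide to its direction or size. What can be said is that compound 1 sits at the strong end of the three numbers, which leaves more room for the number to rise than to fall. On that basis, a modest weakening is expected, a 2.2-fold higher number from compound 1 to compound 4 (0.34 log units; beyond the scatter), with wide uncertainty. Compound 4 is therefore estimated at 350 nM in this assay, within a range from 90 nM to 1400 nM.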

Compound 4, inhibition constant: 19 nM
Estimate against measurement, compound 4: 18-fold (1.27 log units) above; the measured number lies below the stated range.
By their numbers in this assay, from the lowest: compound 4; then compound 1; then compound 3; then compound 2.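

Going by these compounds alone, the position on the aromatic carbon, which no earlier pair touched, proves able to carry a much larger group in this assay: putting 1-(((aminomethyl)carbonyl)amino)-3-methylbutyl, with 10 heavy atoms, in place of 1-amino-2-methylbutyl, with 6, gives an 8.4-fold lower number from compound 1 to compound 4 (0.93 log units; beyond the scatter). This single step bundles several changes, as the methyl branch moves along the chain, the amine gains an aminomethyl carbonyl group, and the entering group has a defined stereocentre, so the step cannot show which of these carries the lower number. No measurement at hand accounts for the step.

The compounds shown leave open whether a plain 1-amino-3-methylbutyl group alongside the same carbonyl chain as in compound 1 would already shift the number, and whether an acetyl group on that nitrogen, without the terminal amine, would keep the gain. They also leave open how a longer chain between the amide carbonyl and the terminal amine, or a carboxylic acid in place of that amine, would read in this assay.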